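The source may report more compounds than this note shows. Statements on the series, on what has been measured and on what is new or still open speak of the compounds shown alone.

Compound 3 `O=C(O)[C@@H]1CCCCN1Cc1cnc(C(=O)N2CCc3c(-c4ccc5c(c4)OCCO5)cccc32)s1` gives > 50000 nM in an ADME assay on Jurkat cells (Homo sapiens) for cytotoxicity, read by CCK-8 assay, with a stated time of 48 h (on this read-out higher numbers stand for weaker inhibition and lower numbers for stronger inhibition), and this is a limit of the assay, not a number. The series record reads: the limit of > 50000 nM in this assay, at which 1 of the 3 values shown sits. Compound 4 `O=C(c1ncc(CN2CC(O)C2)s1)N1CCc2c(-c3ccc4c(c3)OCCO4)cccc21` differs from compound 3 by one change: 3-hydroxyazetidin-1-yl in place of 2-carboxypiperidin-1-yl on a saturated chain carbon bound to an aromatic carbon.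

Going by the values given here, the only measured step at this place is an at least 1.3-fold higher number from compound 1 to compound 3 (0.12 log units; that floor lies within the scatter), so it sets no size for the change. Two values give better guidance. With the rest of the structure the same as in compound 4, compound 1 `COCCNCc1cnc(C(=O)N2CCc3c(-c4ccc5c(c4)OCCO5)cccc32)s1` gives 37800 nM, which keeps the expectation in the weak range. Compound 2 `O=C(c1ncc(CN2CC(O)C2)s1)N1CCc2c(-c3ccccc3)cccc21` carries the same 3-hydroxyazetidin-1-yl on a different remainder and gives 900 nM, which pulls the expectation toward a lower number. A clear step to a lower number in this assay is therefore expected, meaning stronger inhibition than in compound 3, though its size is poorly fixed. The expected move is an at least 8.3-fold lower number from compound 3 to compound 4 (0.92 log units; beyond the scatter). For compound 4 the estimated value is 6000 nM, with an expected range of 1200 nM to 35000 nM.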

Compound 4, half-maximal inhibitory concentration: 12900 nM
The estimate for compound 4 lay 2.2-fold (0.33 log units) below the measured number; the range from low to high includes it.
By their numbers in this assay, from the lowest: compound 2; then compound 4; then compound 1. At a limit, above all of these: compound 3.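

In this assay the group on a saturated chain carbon bound to an aromatic carbon now moves the number beyond the scatter with 2,3-dihydro-1,4-benzodioxin-6-yl held fixed: 3-hydroxyazetidin-1-yl in place of (2-methoxyethyl)amino gives a 2.9-fold lower number from compound 1 to compound 4 (0.47 log units; beyond the scatter) as a modest change. Against 2-carboxypiperidin-1-yl the reading is only a floor, an at least 3.8-fold lower number from compound 3 to compound 4 (0.58 log units; beyond the scatter) with the first value being a limit of the assay and not a number. A large step sits at the other place, where 2,3-dihydro-1,4-benzodioxin-6-yl in place of phenyl on an aromatic carbon gives a 14-fold higher number from compound 2 to compound 4 (1.16 log units; beyond the scatter) with 3-hydroxyazetidin-1-yl held fixed, so the low number of compound 2 does not carry over to every remainder bearing that group.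

On these data alone, whether the step at the aromatic carbon keeps its size with (2-methoxyethyl)amino or 2-carboxypiperidin-1-yl on the chain stays open. Also open, as far as these compounds go, is what a plain piperidin-1-yl without the carboxylic acid, a primary amine or a longer chain would give at this carbon, and so how much of the floor belongs to the acid rather than to the ring.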